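Hydrogen in place of benzyl on compound 1

The source may report more compounds than this note shows. Statements on the series, on what has been measured and on what is new or still open speak of the compounds shown alone.

Measured so far (in a physicochemical assay for solubility, read by nephelometry, measured as kinetic solubility, at pH 2.0; on this read-out lower numbers stand for lower solubility and higher numbers for higher solubility):
- compound 1 `NCc1csc(NC(=O)c2cnnn2Cc2ccccc2)n1` gives > 100 ug/mL (a limit)
- compound 2 `NCc1csc(NC(=O)c2cc3ccccc3n2Cc2ccccc2)n1` gives 25 ug/mL (a number)
- compound 3 `CC(C)(C)c1cc(C(=O)Nc2nc(CO)cs2)n(Cc2ccccc2)n1` gives 12.5 ug/mL (a number)

Compound 1 gives > 100 ug/mL as a limit of the assay and not as a number. It therefore stands at the limit of > 100 ug/mL in this assay, at which 1 of the 3 values shown sits, and has no exact position. Compound 2 at 25 ug/mL and compound 3 at 12.5 ug/mL lie within the usual scatter of each other. Going by the values given here, no two measured compounds differ in one place only, so the series gives no measured size for a single change.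

The next compound is compound 4 `NCc1csc(NC(=O)c2cnn[nH]2)n1`, not yet measured in this assay. Its difference from compound 1 is hydrogen in place of benzyl on an aromatic nitrogen and amounts to hydrogen in place of benzyl on an aromatic nitrogen. The expectation rests on compound 1 at > 100 ug/mL (again only a limit). No step beyond the scatter is expected, and the estimated a number no higher from compound 1 to compound 4 (the limit leaves the size open) is given with that in mind. A further report as a limit is the likely outcome. For compound 4 the expected value is 100 ug/mL (estimated range 50 ug/mL to 200 ug/mL).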

Compound 4, solubility: > 100 ug/mL
Compound 4: only a limit was reported; the forecaster's own chance of this, stated with the estimate: 70%; the middle value sits exactly at the limit.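

Compound 1 and compound 4 are both reported only as limits in this assay, so no step between them can be read: the limit of > 100 ug/mL in this assay, at which 2 of the 4 values shown sit.

The compounds shown leave open what size of step, if any, hydrogen in place of benzyl on an aromatic nitrogen produces in this assay, as neither compound has an exact value.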